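The source may hold more compounds than are shown below. What is called first, only, known or untested is meant among the compounds shown, and "the series" means these compounds.

The measured compounds:
Compound 1 `COC(=O)c1cc(-c2cccc(NC(=O)c3ccc(/C=C/C(=O)c4cc(OC)c(OC)c(OC)c4)cc3)c2)on1`: in an ADME assay on Vero cells (Chlorocebus sabaeus) for cytotoxicity, read by MTT assay, with a stated time of 72 h (a higher number here means that more compound is tolerated, a lower number that less compound is tolerated), compound 1 gives > 50 ug/mL, a limit of the assay.
Compound 2 `COC(=O)c1cc(-c2cccc(NC(=O)c3ccc(/C=C/C(=O)c4ccccc4Cl)cc3)c2)on1`: in this assay compound 2 gives > 25 ug/mL, also a limit of the assay and not a number.

For the measured compounds named here, compound 2 therefore stands only at a limit in this assay, and the one further value shown, that of compound 1, is a limit as well. The step that the two limits leave unreadable from compound 1 to compound 2 cannot be read, because one value sits at the limit of > 25 ug/mL in this assay, at which 1 of the 2 values shown sits, and the other at the limit of > 50 ug/mL in this assay, at which 1 of the 2 values shown sits.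

Compound 3 `COC(=O)c1cc(-c2cccc(NC(=O)c3ccc(/C=C/C(=O)c4ccc(OC)c([N+](=O)[O-])c4)cc3)c2)on1` differs from compound 2 in one place: 4-methoxy-3-nitrophenyl in place of 2-chlorophenyl on a carbonyl carbon. Going by the values given here, the only measured step touches the same position but has no readable size, so it gives neither a direction nor a magnitude for the change from compound 2 to compound 3. With both measured compounds sitting at limits, compound 3 is expected to remain in the same region, and the expected step that the limit leaves unreadable from compound 2 to compound 3 is none beyond the scatter. Compound 3 is thus estimated at 50 ug/mL, with a range from 25 ug/mL to 100 ug/mL, and most likely this assay would again report only a limit for it.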

Compound 3, half-maximal cytotoxic concentration: > 40 ug/mL
Compound 3: a limit, no number; the forecaster's own chance of this, stated with the estimate: 70%; the middle value lies beyond the limit too.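

In this assay compound 3 gives > 40 ug/mL, a limit of the assay and not a number. For the compounds shown here, compound 1 and compound 2 also stand at limits, so no step among compound 1, compound 2 and compound 3 can be read. The compounds shown leave open whether the groups on the carbonyl carbon change cytotoxicity at all.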